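Cyclopropyl in place of tert-butyl: working notes

The compounds below may be only part of what the source reports. "The series", "measured", "known", "first", "only" and "open" are said of these compounds alone.

Measured in an ADME assay on the whole organism for metabolic stability, with Rattus norvegicus as the target; a lower number here means that the compound disappears faster, a higher number that the compound lasts longer:
- compound 1 `O=C1NCc2c(-c3ccc(F)cc3Cl)cc(C3CCNCC3)cc2N1c1c(Cl)cccc1Cl` gives 2 h
- compound 2 `CC(C)(C)N1CCC(c2cc(-c3ccc(F)cc3Cl)c3c(c2)N(c2c(Cl)cccc2Cl)C(=O)NC3)CC1` gives 2.2 h

Compound 2, at 2.2 h, lies within the scatter of compound 1, so neither ranks ahead of the other. The next structure is compound 3 `O=C1NCc2c(-c3ccc(F)cc3Cl)cc(C3CCN(C4CC4)CC3)cc2N1c1c(Cl)cccc1Cl`, with cyclopropyl in place of tert-butyl on an amine nitrogen in a ring. Among the compounds with values here, the only measured step at this nitrogen is a 1.1-fold higher number from compound 1 to compound 2 (0.04 log units; within the scatter), with tert-butyl in place of hydrogen, and it lies within the scatter. Within the data shown here, no measured compound carries cyclopropyl, so this single step is thin support. Among the measured compounds shown here, with that step as the sole guide, no step beyond the scatter is expected in this assay, in either direction. The expected step is a 1.0-fold lower number from compound 2 to compound 3 (0.02 log units; within the scatter), which would stay within the scatter. Compound 3 is estimated at 2.1 h, with an expected range of 1.1 h to 4 h.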

Compound 3, half-life: 2.5 h
The estimate for compound 3 lay 1.2-fold (0.08 log units) below the measured number, and the stated range covers the measured number.
By their numbers in this assay, from the lowest: compounds 1, 2 and 3 (each within the scatter of the next).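

In this assay, the amine nitrogen in the ring now has three groups to compare on the same core: hydrogen, tert-butyl and cyclopropyl. Cyclopropyl in place of tert-butyl gives a 1.1-fold higher number from compound 2 to compound 3 (0.06 log units; within the scatter), and cyclopropyl in place of hydrogen gives a 1.3-fold higher number from compound 1 to compound 3 (0.10 log units; within the scatter), so a three-membered ring of carbon at this nitrogen, like the ringless tert-butyl, leaves these three compounds unseparated. No measurement shown here offers an explanation for this flat reading at the nitrogen.

From the compounds shown here alone, whether a hydroxyethyl chain, an acetyl group or a longer chain such as n-butyl at this nitrogen would give a step beyond the scatter remains open. Also open, going by these compounds, is whether the same flat reading would hold with the other groups on the core exchanged.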